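The source may report more compounds than this note shows. Statements on the series, on what has been measured and on what is new or still open speak of the compounds shown alone.

Measured so far in a functional assay on HepG2 cells (Homo sapiens) for antiproliferative activity, read by MTT assay, with a stated time of 48 h; a lower number here means a stronger inhibitor, a higher number a weaker inhibitor: compound 1 `Clc1cccc(Nc2ncnc3ccc(NCc4c[nH]c5ccccc45)cc23)c1` gives 5260 nM. Compound 2 `CSCCCNc1ccc2ncnc(Nc3cccc(Cl)c3)c2c1` gives 8920 nM. Compound 3 `O=C(/C=C/c1cccc(Br)n1)Nc1ccc2ncnc(Nc3cccc(Cl)c3)c2c1` gives 10700 nM.

Compound 3 gives a higher number than compound 1, a gap beyond the scatter, while compound 2 and compound 3 lie within the scatter of one another. Within the data shown here, the only step measured between close neighbours, a 1.7-fold higher number from compound 1 to compound 2 (0.23 log units; within the scatter), changes a different part of the molecule, a side chain on a ring nitrogen.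

Compound 4 `O=C(/C=C/c1cccnc1Cl)Nc1ccc2ncnc(Nc3cccc(Cl)c3)c2c1` differs from compound 3 only by 2-chloropyridin-3-yl in place of 6-bromopyridin-2-yl on a double-bonded chain carbon bound to a double-bonded chain carbon. Among the measured compounds shown here, no measured pair shows this kind of change, so nothing in the data points in either direction. The expected step of a 1.1-fold lower number from compound 3 to compound 4 (0.03 log units; within the scatter) is therefore none beyond the scatter. Compound 4 is estimated at 10000 nM, with a range from 4000 nM to 25000 nM.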

Compound 4, half-maximal inhibitory concentration: 4420 nM
The estimate for compound 4 lay 2.3-fold (0.35 log units) above the measured number; low and high end bracket the measured number.
By their numbers in this assay, from the lowest: compounds 4, 1, 2 and 3 (each within the scatter of the next, the first and the last beyond it).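

In this assay, the group on the double-bonded chain carbon proves able to shift the result: 2-chloropyridin-3-yl in place of 6-bromopyridin-2-yl gives a 2.4-fold lower number from compound 3 to compound 4 (0.38 log units; beyond the scatter). Both groups hold one six-membered aromatic ring with the same number of heavy atoms, yet this step lies beyond the scatter. Nothing available explains why this swap lowers the number.

The step changes the halogen and the arrangement of the pyridine together, and this single pair cannot separate the two. As far as these compounds go, how an unsubstituted phenyl ring or an aminopyridine would behave at this position remains open.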